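Trimming a Biaryl Down to a Nitrile

The source may hold more compounds than are shown below. What is called first, only, known or untested is meant among the compounds shown, and "the series" means these compounds.

Measured so far:
compound 1, `Cc1n[nH]c(C(=O)O)c1Cc1cccc(-c2cccc(F)c2)c1`: 50%
compound 2, `Cc1n[nH]c(C(=O)O)c1Cc1ccc2ccccc2n1`: 18%

Within the data shown here, in an assay on isolated protein for inhibition of 2-Hydroxyacid oxidase 2 (Homo sapiens), tested at 10 uM (a lower number here means a weaker effect, a higher number a stronger effect of the compound at the concentration tested), compound 1 gives 50%, the higher of the two numbers measured so far. Compound 2 gives 18% in this assay, a number that lies below compound 1 by more than the usual scatter. Among the measured compounds shown here, no pair of measured compounds differs in a single place, so nothing measured yet tells how much any one change shifts the read-out.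

Compound 3, `Cc1n[nH]c(C(=O)O)c1Cc1cccc(C#N)c1`, has not yet been measured. It differs from compound 1 in one place: cyano in place of 3-fluorophenyl on an aromatic carbon. A whole six-membered aromatic ring of carbon only, carrying its fluorine, is removed, and a group of just two heavy atoms takes its spot on an aromatic carbon, meta to a large group. For the measured compounds named here, with no measured step to lean on, the expectation rests on the loss of so much of the structure: in this assay the step is expected to be a number 25 percentage points lower from compound 1 to compound 3 (beyond the scatter), a decrease beyond the scatter. Compound 3 is therefore estimated at 25%, within a range from 5% to 45%.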

Compound 3, a percentage reported as inhibition, at one concentration (the size of the read-out at that concentration, not a potency): 19%
Estimate against measurement, compound 3: 6 percentage points above; the range from low to high includes it.
By their numbers in this assay, from the lowest: compounds 2 and 3 (each within the scatter of the next); then compound 1.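

Swapping 3-fluorophenyl for cyano on this aromatic carbon gives the first single-place comparison in this assay, and the read-out falls by a number 31 percentage points lower from compound 1 to compound 3 (beyond the scatter) in a step classed as large. This shows that the group at this position matters to the read-out: with 7 heavy atoms and a six-membered aromatic ring in place the value is clearly higher than with the 2 heavy atoms of cyano, so this carbon is not a spot where any substituent will do. Among these compounds, nothing available explains why the read-out drops with this swap and the single step only gives its size.

The change removes the ring and its fluorine and introduces the nitrile all at once, so the compounds shown do not separate what each of these contributes. Open questions are whether an unsubstituted phenyl would hold the read-out of compound 1 without the fluorine, and whether a mid-sized group such as a methoxy or a longer chain such as a benzyloxy would recover part of the loss seen with compound 3 at this same position.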